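A few compounds are considered here, and "the series" means these few. Any claim that something is new, unique, unknown or untested is made for them only; others in the source may bear on it.

Measured compounds:
- compound 1, `COc1ccc(/C=N/NC(=O)Nc2ccc(Oc3ccnc(-c4nncn4CCN(C)C)c3)c(F)c2)c(OC)c1`: 6630 nM
- compound 2, `CN(C)CCn1cnnc1-c1cc(Oc2ccc(NC(=O)N/N=C/c3ccc(O)cc3)cc2F)ccn1`: "not determined" (no result reported)

In an ADME assay on WI-38 cells (Homo sapiens) for cytotoxicity, read by MTT assay, with a stated time of 72 h (a higher number here means a weaker inhibitor, a lower number a stronger inhibitor), compound 1 gives 6630 nM. Among the compounds with values here, for compound 2 the same this assay records only "not determined" (no result reported), so compound 2 stands without a number and no step to compound 1 can be stated; the two structures differ on the aryl carried by the hydrazone, and nothing more can be read from the pair.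

Compound 3, `CN(C)CCn1cnnc1-c1cc(Oc2ccc(NC(=O)N/N=C/c3ccc(F)cc3Cl)cc2F)ccn1`, is the next member to be measured in this assay. It differs from compound 2 by 2-chloro-4-fluorophenyl in place of 4-hydroxyphenyl on a carbon with a double bond to nitrogen. Within the data shown here, no measured step informs the size of this change, and the only anchor is compound 1 with 6630 nM in this assay, a close analogue in the shared core. Compound 3 is expected to land in the same region as compound 1 in this assay, with no directional shift claimed beyond the scatter. For compound 3 the estimate in this assay is 7000 nM, with a range from 2500 nM to 20000 nM.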

Compound 3, half-maximal inhibitory concentration: 2090 nM
Estimate against measurement, compound 3: 3.3-fold (0.52 log units) above; the whole stated range lies above it.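

In this assay, the group on a carbon with a double bond to nitrogen is shown to move the read-out: 2-chloro-4-fluorophenyl in place of 2,4-dimethoxyphenyl gives a 3.2-fold lower number from compound 1 to compound 3 (0.50 log units; beyond the scatter), so the shared core does not hold the value at one level. The change from 4-hydroxyphenyl in compound 2 to the same halogenated aryl in compound 3 cannot be read, as compound 2 has no number. No measurement shown here accounts for the size or direction of the step.

Still open is whether the chlorine, the fluorine or the pair carries the step, as 2-chlorophenyl and 4-fluorophenyl are not among the compounds shown. Also open, from the compounds shown here alone, is where an aryl bearing an amine or a carboxylic acid in this place would fall in this assay.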